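A few compounds are considered here, and "the series" means these few. Any claim that something is new, unique, unknown or untested is made for them only; others in the source may bear on it.

Values in a functional assay on MKN-74 cells (Homo sapiens) for antiproliferative activity, with a stated time of 24 h; a higher number here means a weaker inhibitor, a lower number a stronger inhibitor:

compound 1 `NC(=O)c1c(NC(=O)c2ccccc2Cl)sc2c1CCN(Cc1ccccc1)C2`: 14500 nM
compound 2 `NC(=O)c1c(NC(=O)c2ccccc2Cl)sc2c1CCN(C(=S)Nc1ccccc1F)C2`: 12600 nM

Compound 2 stands at the lowest of the two numbers, yet the step of a 1.2-fold lower number from compound 1 to compound 2 (0.06 log units; within the scatter) lies within the scatter, so no order between compound 1 and compound 2 can be read from this assay. Within the data shown here, that single step concerns the group on the amine nitrogen in the ring and is the only measured step.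

Compound 3 `NC(=O)c1c(NC(=O)c2ccccc2Br)sc2c1CCN(C(=S)Nc1ccccc1F)C2` differs from compound 2 by bromo in place of chloro on an aromatic carbon. Among the measured compounds shown here, no measured step touches this halogen position, so nothing in the data points to a shift in either direction. For the measured compounds named here, the one step that is known was itself within the scatter. The expectation is therefore a step of no size beyond the scatter, a 1.1-fold lower number from compound 2 to compound 3 (0.02 log units; within the scatter).

Compound 3 is estimated at 12000 nM in this assay, with a range from 6000 nM to 25000 nM.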

Compound 3, half-maximal inhibitory concentration: > 50000 nM
Compound 3 was reported as a limit (the forecaster's own chance of this, stated with the estimate: 5%); middle value at least 4.1-fold (0.61 log units) away from the limit.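

Bromo in place of chloro on this aromatic carbon, ortho to a large group, gives an at least 3.9-fold higher number from compound 2 to compound 3 (0.59 log units; beyond the scatter) in this assay. Among these compounds, this position therefore responds to the exchange of one heavy atom for another, whereas the only earlier step, a 1.2-fold lower number from compound 1 to compound 2 (0.06 log units; within the scatter), on the amine nitrogen in the ring, stayed within the scatter. Compound 3 is reported only as a limit, so the step gives a minimum and not a size: the limit of > 50000 nM in this assay, at which 1 of the 3 values shown sits.

Chloro and bromo have the same counts of heavy atoms, hydrogen-bond donors and acceptors, and neither carries a net charge, so these counts do not explain the step. As far as these compounds go, it remains open how a fluoro group, a methyl group or plain hydrogen on this carbon would read, and whether bromo gives the same step with the amine-nitrogen group of compound 1.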